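A few compounds are considered here, and "the series" means these few. Any claim that something is new, unique, unknown or untested is made for them only; others in the source may bear on it.

Measured compounds:
- compound 1, `CC1(C)CC(=O)C=C(Nc2ccc(Cl)cc2)C1`, in a functional assay on PBMC cells (Homo sapiens) for inhibition, read by ELISA, with a stated time of 18 h (a higher number here means a weaker inhibitor, a lower number a stronger inhibitor), gives > 20 ug/mL, which is a limit of the assay.
- compound 2, `CC1(C)CC(=O)C(C(=S)SCCO)=C(Nc2ccc(Cl)cc2)C1`, in this assay gives > 20 ug/mL, which is also a limit.

Among the measured compounds shown here, compound 1 therefore stands at the limit of this assay: no number is known for it, only that its value lies beyond the reach of the assay. For the measured compounds named here, the one further value shown, that of compound 2, is a limit as well, so that the limit of > 20 ug/mL in this assay, at which 2 of the 2 values shown sit, describes where both compounds sit. Going by the values given here, the single measured step, a step that the two limits leave unreadable from compound 1 to compound 2, cannot be read, both of its ends being limits.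

Compound 3, `CC1(C)CC(=O)C=C(Nc2ccc(Br)cc2)C1`, differs from compound 1 by bromo in place of chloro on an aromatic carbon. Among the compounds with values here, no measured step bears on this change; the only step known, a step that the two limits leave unreadable from compound 1 to compound 2, concerns a different change and gives no size. The expectation for compound 3 is therefore that this assay reports a limit once more, and the estimated step that the limit leaves unreadable from compound 1 to compound 3 is none beyond the scatter. Compound 3 is estimated at 25 ug/mL, with a range from 12 ug/mL to 60 ug/mL.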

Compound 3, half-maximal inhibitory concentration: > 20 ug/mL
Compound 3 ended at the assay's limit (the forecaster's own chance of this, stated with the estimate: 85%); the middle value is on the limit's open side.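

In this assay, no step can be read from compound 1 to compound 3, so the swap of chloro for bromo has no readable size; all three compounds sit at one limit: the limit of > 20 ug/mL in this assay, at which 3 of the 3 values shown sit.

The compounds shown leave open how strongly any of them inhibits, and which change to the shared core would give a value within the reach of this assay.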